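The source may report more compounds than this note shows. Statements on the series, on what has been measured and on what is new or still open speak of the compounds shown alone.

Working notes on the series. In an ADME assay on microsomes from liver (Homo sapiens) for metabolic stability (a lower number here means slower removal, a higher number faster removal of the compound), compound 1 (`CC(=O)N[C@@H]1CCC[C@H](C(=O)Nc2cc(-c3cnc4n3CCC4)c(Cl)cn2)C1`) gives 9.7 mL.min-1.g-1 and compound 2 (`CC(=O)N[C@@H]1CCC[C@H](C(=O)Nc2cc(-c3cnn4c3CCCCC4)c(Cl)cn2)C1`) gives 39 mL.min-1.g-1. Compound 3 (`CC(=O)N[C@@H]1CCC[C@H](C(=O)Nc2cc(-c3cnn4c3CN(C)CC4)c(Cl)cn2)C1`) reads < 3 mL.min-1.g-1, which is a limit of the assay and not a number. It stands lowest of the three, with an at least 3.2-fold lower number from compound 1 to compound 3 (0.50 log units; beyond the scatter) and an at least 13-fold lower number from compound 2 to compound 3 (1.11 log units; beyond the scatter).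

Compound 4 (`CC(=O)N[C@@H]1CCC[C@H](C(=O)Nc2cc(-c3cnn4c3OCCC4)c(Cl)cn2)C1`) is not yet measured in this assay. The change is a group of 9 heavy atoms (6 carbon, 2 nitrogen, 1 oxygen; one five-membered aromatic ring with 2 hetero atoms, one six-membered non-aromatic ring with 2 hetero atoms) in place of a group of 10 heavy atoms (7 carbon, 3 nitrogen; one five-membered aromatic ring with 2 hetero atoms, one six-membered non-aromatic ring with 2 hetero atoms), on an aromatic carbon. Going by the values given here, no measured step isolates this exchange. The nearest evidence comes from the steps at the same place, which include a 4.0-fold higher number from compound 1 to compound 2 (0.60 log units; beyond the scatter), so exchanges here have moved the number beyond the scatter. Compound 4 shares its ring sizes with compound 3, but its group has lost a nitrogen and gained an oxygen. A modest rise is therefore expected, towards compound 1 at 9.7 mL.min-1.g-1, with compound 2 at 39 mL.min-1.g-1 well out of reach. The estimated step is an at least 2.6-fold higher number from compound 3 to compound 4 (0.42 log units; beyond the scatter). For compound 4 the estimated value is 8 mL.min-1.g-1, with an expected range of 3 mL.min-1.g-1 to 20 mL.min-1.g-1.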

Compound 4, intrinsic clearance in microsomes: < 3 mL.min-1.g-1
Compound 4 was reported as a limit; the forecaster's own chance of this, stated with the estimate: 20%; at least 2.6-fold (0.42 log units) between middle value and limit.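

In this assay compound 4 reads as a limit of the assay, as compound 3 does, so the step between them cannot be read: the limit of < 3 mL.min-1.g-1 in this assay, at which 2 of the 4 values shown sit.

The lowest reading at this position is therefore no longer tied to the group of compound 3, since a group of 9 heavy atoms holding an oxygen and one nitrogen fewer reaches it too. That group also sits clear of the other two groups, with an at least 13-fold lower number from compound 2 to compound 4 (1.11 log units; beyond the scatter) and an at least 3.2-fold lower number from compound 1 to compound 4 (0.50 log units; beyond the scatter).

From the compounds shown here alone, how far compound 3 and compound 4 each lie past the limit stays open, so no order between them can be given. Also open, going by these compounds, is whether a group with a sulfur atom in place of that oxygen would stay at the limit.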